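The compounds below may be only part of what the source reports. "The series", "measured", "known", "first", "only" and "open" are said of these compounds alone.

Compound 3, `CC(C)=CCC/C(C)=C/CC1Cc2c(OCCCOc3ccc(Cl)cc3)cc(=O)n(CCCO)c2CC1(C)C`, stands in a functional assay on PANC-1 cells (Homo sapiens) for inhibition, read by MTT assay, with a stated time of 24 h, tested at 10 uM (on this read-out lower numbers stand for less inhibition and higher numbers for more inhibition at the one concentration tested (going by the name of the read-out)), at 0%, level with both measured relatives. Compound 1, `CC(C)=CCC/C(C)=C/CC1Cc2c(O)cc(=O)n(CCCO)c2CC1(C)C`, gives 0%, and compound 2, `CC(C)=CCC/C(C)=C/CC1Cc2c(OCCCNS(=O)(=O)c3ccc(Br)cc3)cc(=O)n(CCCO)c2CC1(C)C`, gives 0%. The two steps reaching compound 3 are no change at the digits printed from compound 1 to compound 3 (within the scatter) and no change at the digits printed from compound 2 to compound 3 (within the scatter), so neither adding a large group on the aromatic oxygen nor exchanging the group at the end of that chain has shifted the read-out. Compound 4, `CC(C)=CCC/C(C)=C/CC1Cc2c(OC(=O)Nc3ccc(F)c(F)c3)cc(=O)n(CCCO)c2CC1(C)C`, differs from compound 3 by (3,4-difluorophenyl)carbamoyl in place of 3-(4-chlorophenoxy)propyl on an oxygen on an aromatic ring. For the measured compounds named here, no measured step tests a carbamoyl on that oxygen, but every step seen so far lies within the scatter, so compound 4 is expected to remain unchanged, with a number 2 percentage points higher from compound 3 to compound 4 (within the scatter). The estimate for compound 4 is 2%, expected to fall between -5% and 15%.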

Compound 4, a percentage reported as inhibition, at one concentration (the size of the read-out at that concentration, not a potency): 4.8%
Estimate against measurement, compound 4: 2.8 percentage points below; measured number inside the range.
By their numbers in this assay, from the lowest: compounds 1, 2, 3 and 4 (each within the scatter of the next).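

Placing (3,4-difluorophenyl)carbamoyl on this oxygen on an aromatic ring, where only hydrogen and ether-linked chains had stood, stays flat in this assay with a number 4.8 percentage points higher from compound 3 to compound 4 (within the scatter) and with a number 4.8 percentage points higher from compound 1 to compound 4 (within the scatter). For the compounds shown here, the flat read-out therefore extends to a carbamoyl link with an aryl group at its end, and no step at this position has yet left the scatter. Nothing measured here offers an explanation for this flat read-out. Going by these compounds, whether an amine, a carboxylic acid or a longer chain on this oxygen would move the read-out remains open. So does the effect of any change elsewhere on the shared core, which all four compounds keep intact.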